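Swapping the aryl group on the piperazine of compound 1

The compounds below may be only part of what the source reports. "The series", "measured", "known", "first", "only" and "open" are said of these compounds alone.

Compound 1 `CCC1(CCCCN2CCN(c3ccc(Cl)cc3)CC2)C(=O)Nc2ccccc21` was tested in a functional assay on the whole organism (strain Wistar) with Rattus norvegicus as the target, with a stated time of 5 min (a higher number here means that more compound is needed for the effect, a lower number that less compound is needed), where compound 1 gives 10 mg/kg. Compound 3 `CCC1(CCCCN2CCN(c3cccc(Cl)c3)CC2)C(=O)Nc2cc(F)c(Cl)cc21` gives 20 mg/kg in this assay, a number that lies within the usual scatter of the value for compound 1, so the two cannot be told apart. For compound 2 `CCC1(CCCCN2CC=C(c3ccc(Cl)cc3)CC2)C(=O)Nc2ccccc21` this assay reports only a limit, > 20 mg/kg, the limit of > 20 mg/kg in this assay, at which 1 of the 3 values shown sits, being the only such case among these results.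

The untested compound 4 `CCC1(CCCCN2CCN(c3cccc(OC)c3)CC2)C(=O)Nc2ccccc21` differs from compound 1 in one place: 3-methoxyphenyl in place of 4-chlorophenyl on an amine nitrogen in a ring. Among the measured compounds shown here, no measured pair shows this kind of change, so there is no direct guide to its effect. With so few comparisons, the expectation is a step from compound 1 to compound 4 of a 2.0-fold higher number from compound 1 to compound 4 (0.30 log units; within the scatter) in this assay, a shift towards a larger dose but one that may not go beyond the scatter. Compound 4 is therefore estimated to need 20 mg/kg, with a likely range from 7 mg/kg to 60 mg/kg.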

Compound 4, minimum effective dose: > 20 mg/kg
Compound 4: only a limit was reported; the forecaster's own chance of this, stated with the estimate: 35%; the middle value sits exactly at the limit.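

In this assay, among the compounds shown here, the swap to 3-methoxyphenyl in place of 4-chlorophenyl on an amine nitrogen in a ring gives the first measured step at this position: an at least 2.0-fold higher number from compound 1 to compound 4 (0.30 log units; that floor lies within the scatter). Going by these compounds, the result for compound 4 is a limit and not a number, so the true size of the step stays unknown, and its floor does not clear the scatter; what it does show is that this swap brings no sign of a lower dose. Compound 4 thereby becomes the second case of this limit: the limit of > 20 mg/kg in this assay, at which 2 of the 4 values shown sit.

Which part of the change matters, the methoxy group or the place it holds on the phenyl ring, stays open, and a 4-methoxyphenyl group on the core of compound 1 would tell the two apart. On these data alone, how a plain phenyl group at this nitrogen would compare also stays open.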